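Imidazolyl-indane series: pyrazolyl replaces the ethylsulfonylamino group

This account rests on a few compounds, and the source may have more. Where it says the series, first, only, none or still open, it means among the compounds named here.

Measured compounds:
compound 1 `CCS(=O)(=O)Nc1cccc2c1CCC2c1ncc[nH]1`: > 10000 nM
compound 2 `CS(=O)(=O)Nc1cccc2c1CCCC2c1ncc[nH]1`: > 10000 nM; > 10000 nM; > 10000 nM (3 entries)

Two compounds have been characterised so far in a functional assay on CHO cells for agonist activity at Alpha-1D adrenergic receptor (Homo sapiens), read by FLIPR and calcium flux; a higher number here means that more compound is needed for the effect, a lower number that less compound is needed. Compound 1 carries an (ethylsulfonyl)amino group on the shared core; in this assay compound 1 gives > 10000 nM, which is a limit of the assay rather than a number. Compound 2 carries a (methylsulfonyl)amino group on a core with a six-membered saturated ring; in this assay compound 2 gives > 10000 nM; > 10000 nM; > 10000 nM (3 entries), each entry again a limit. Compound 1 therefore stands at the limit of > 10000 nM in this assay, at which 1 of the 2 values shown sits, and no value below that limit is available for it. For the measured compounds named here, since no pair of compounds differs in a single place, no measured step can be drawn from these data.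

Compound 3 `c1cc(-c2ccn[nH]2)c2c(c1)C(c1ncc[nH]1)CC2` is not yet measured. It differs from compound 1 by 1H-pyrazol-5-yl in place of (ethylsulfonyl)amino on an aromatic carbon. Going by the values given here, with both measured compounds sitting at the limit, there is no step on which to ground a direction, and the estimate for compound 3 is expected to remain close to that limit: compound 3 is estimated at 10000 nM (range 1500 nM to 40000 nM), which corresponds to an expected step of a number no higher from compound 1 to compound 3 (the limit leaves the size open).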

Compound 3, half-maximal effective concentration: 336 nM
Compound 3: the middle estimate sits 30-fold (1.47 log units) above what was measured; measured number outside the range, below it.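

In this assay, placing 1H-pyrazol-5-yl in place of (ethylsulfonyl)amino on the aromatic carbon ortho to a fused ring gives an at least 29-fold lower number from compound 1 to compound 3 (1.47 log units; beyond the scatter). This makes compound 3 the first of the compounds shown with a measured number rather than a limit, at 336 nM, so the earlier finding that neither sulfonylamino compound reached a number does not extend to every group at this position. The step is open-ended, and the true gap may be larger than printed, since compound 1 gives only a limit of the assay: the limit of > 10000 nM in this assay, at which 1 of the 3 values shown sits.

The compounds shown leave open whether the gain belongs to the five-membered aromatic ring with its 2 hetero atoms or would also appear with another group on the same carbon, such as a phenyl ring, a pyridine ring, a primary amine or a carboxylic acid. They also leave open whether 1H-pyrazol-5-yl would have a similar effect on the core of compound 2 with its six-membered saturated ring, as compound 2 and compound 3 differ in more than one place and cannot be compared directly.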